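The compounds below may be only part of what the source reports. "The series", "measured", "known", "first", "only" and "open" are said of these compounds alone.

Of the compounds shown here, three with a shared core have been measured. Compound 1 `COc1cc2c(Oc3ccc(NC(=O)c4cn(-c5ccccc5)nn4)cc3F)ccnc2cc1OCCCN1CCCC1` gives 360 nM in a functional assay on A549 cells (Homo sapiens) for cytotoxicity, read by MTT assay, with a stated time of 72 h; on this read-out lower numbers stand for stronger inhibition and higher numbers for weaker inhibition. Compound 2 `COc1cc2c(Oc3ccc(NC(=O)c4cn(-c5ccccc5Cl)nn4)cc3F)ccnc2cc1OCCCN1CCCC1` gives 330 nM in this assay, and the step of a 1.1-fold lower number from compound 1 to compound 2 (0.04 log units; within the scatter) shows that a chloro in place of hydrogen on the aromatic carbon left the read-out essentially unchanged. Compound 3 `COc1cc2c(Oc3ccc(NC(=O)c4cn(-c5ccccc5Cl)nn4)cc3F)ccnc2cc1OCCCN1CCC(C)CC1` gives 370 nM in this assay; the step of a 1.1-fold higher number from compound 2 to compound 3 (0.05 log units; within the scatter) was likewise within the scatter, so compound 3 sits alongside compound 1 and compound 2, with no separation among the three that the measurement can resolve.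

Compound 4 `COc1cc2c(Oc3ccc(NC(=O)c4cn(-c5c(Cl)cccc5Cl)nn4)cc3F)ccnc2cc1OCCCN1CCC(C)CC1` has not yet been measured. Compared with compound 3 the change is chloro in place of hydrogen on an aromatic carbon: a chloro enters on an aromatic carbon of a six-membered aromatic ring of carbon only, ortho to a large group and meta to a chloro group, so that the 2-chlorophenyl becomes 2,6-dichlorophenyl. Within the data shown here, the only step that bears on this is the first chloro added in the step from compound 1 to compound 2, which stayed within the scatter. A second chloro on the same ring is therefore expected to move the number little, and the expected step of a 1.0-fold higher number from compound 3 to compound 4 (0.01 log units; within the scatter) is one that stays within the scatter. Compound 4 is accordingly estimated at 380 nM, with a range from 190 nM to 760 nM.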

Compound 4, half-maximal inhibitory concentration: 320 nM
Compound 4: middle estimate off by 1.2-fold (0.07 log units), on the high side, and the stated range covers the measured number.
By their numbers in this assay, from the lowest: compounds 4, 2, 1 and 3 (each within the scatter of the next).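

In this assay, the step of a 1.2-fold lower number from compound 3 to compound 4 (0.06 log units; within the scatter) shows that a second chloro on this ring, on an aromatic carbon ortho to a large group and meta to a chloro group, leaves the read-out where it was. The earlier compounds shown here showed only a first chloro entering an unsubstituted phenyl on the core that carries pyrrolidin-1-yl, whereas here the change starts from 2-chlorophenyl and ends at 2,6-dichlorophenyl on the core that carries 4-methylpiperidin-1-yl. The chloro step therefore reads alike in both settings: the same change on two cores in this assay, a 1.1-fold lower number (0.04 log units; within the scatter) from compound 1 to compound 2 and a 1.2-fold lower number (0.06 log units; within the scatter) from compound 3 to compound 4, 1.1-fold (0.03 log units) apart, within the scatter of two such steps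

Among the compounds shown, only hydrogen and chloro stand on this ring, so it remains open whether a different group there, such as methoxy, a nitrile or an amine, would move the number beyond the scatter. The end of the side chain is likewise seen only as pyrrolidin-1-yl or 4-methylpiperidin-1-yl, which leaves open what a morpholine or a dimethylamino group at that place would give in this assay.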